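A Change at the Limit of the Toxicity Read-out

This account rests on a few compounds, and the source may have more. Where it says the series, first, only, none or still open, it means among the compounds named here.

In a functional assay on cells (Macrophage, Homo sapiens) for cytotoxicity (on this read-out higher numbers stand for lower toxicity in this test and lower numbers for higher toxicity in this test), compound 1 `O=C(NN1CCOC1=O)c1[nH]c2ccc(Cl)cc2c1S(=O)(=O)c1ccccc1` gives > 100 uM, which is a limit. Compound 2 `Cc1cc(C)cc(S(=O)(=O)c2c(C(=O)NN3CCOC3=O)[nH]c3ccc(Cl)cc23)c1` gives > 100 uM, also a limit. Compound 3 `Cc1cc(C)cc(S(=O)(=O)c2c(C(=O)NNC(C)C)[nH]c3ccc(Cl)cc23)c1` gives > 100 uM, again a limit. Compound 3 thus stands at the limit of > 100 uM in this assay, at which 3 of the 3 values shown sit.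

Compound 4 `Cc1cc(C)cc(S(=O)(=O)c2c(C(=O)NNC(=O)NN)[nH]c3ccc(Cl)cc23)c1` carries aminocarbamoyl in place of isopropyl on an amine nitrogen. The closest guide is a step that the two limits leave unreadable from compound 2 to compound 3, which changed the group on the same amide-type nitrogen. The other measured change is a step that the two limits leave unreadable from compound 1 to compound 2, made on the sulfonyl sulfur. Neither gives a size, so no shift beyond the scatter is expected in this assay. The expected change is a number no higher from compound 3 to compound 4 (the limit leaves the size open). For compound 4 the estimate is 100 uM, with an expected range of 40 uM to 200 uM.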

Compound 4, half-maximal toxic concentration: > 100 uM
Compound 4 gave a limit, no number; the forecaster's own chance of this, stated with the estimate: 75%; the middle value lies on the limit itself.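

Compound 4, like compound 2 and compound 3, sits at a limit in this assay, so no new step can be read: the limit of > 100 uM in this assay, at which 4 of the 4 values shown sit.
The compounds shown leave open whether any of these changes alters the toxicity at all.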